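The compounds below may be only part of what the source reports. "The series", "measured", "known", "first", "only" and "open" are said of these compounds alone.

Of the compounds shown here, three from this series have been read in a functional assay on HEK293 cells for agonist activity at probable G-protein coupled receptor 27 (Homo sapiens), read by a luciferase reporter and beta-arrestin recruitment, with a stated time of 10 min; a higher number here means that more compound is needed for the effect, a lower number that less compound is needed. Compound 1 `CN(c1ccccc1)S(=O)(=O)c1ccc(NC(=O)c2ccc(Cl)cc2Cl)cc1` gives 2570 nM in this assay. Compound 2 `O=C(Nc1ccc(S(=O)(=O)Nc2ccccc2)cc1)c1ccc(Br)cc1F` gives 479 nM in this assay, which is the lower of the two numbers that were actually read; the nearest other number belongs to compound 1, and the gap between them is beyond the usual scatter of repeated measurements. For compound 3 `O=C(Nc1ccc(Cl)cc1Cl)c1ccc(S(=O)(=O)Nc2ccccc2)cc1` the read-out in this assay is > 100000 nM, which is not a number but (the limit of > 100000 nM in this assay, at which 1 of the 3 values shown sits).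

Compound 4 `Cc1cc(Br)ccc1C(=O)Nc1ccc(S(=O)(=O)Nc2ccccc2)cc1` has not yet been measured. It differs from compound 2 in one place: methyl in place of fluoro on an aromatic carbon. Among the compounds with values here, none of the measured pairs differs by a single change of this kind, so no measured step speaks directly to the swap. With no closer guide, the expectation is a modest shift in this assay, in either direction, of a size that would most likely fall within the scatter; the expected step is a 1.3-fold higher number from compound 2 to compound 4 (0.10 log units; within the scatter). Compound 4 is therefore estimated to give about 600 nM in this assay, with a plausible range from 200 nM to 2000 nM.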

Compound 4, half-maximal effective concentration: 851 nM
Estimate against measurement, compound 4: 1.4-fold (0.15 log units) below, and the stated range covers the measured number.
By their numbers in this assay, from the lowest: compounds 2 and 4 (each within the scatter of the next); then compound 1. At a limit, above all of these: compound 3.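

In this assay, the swap of fluoro for methyl gives a 1.8-fold higher number from compound 2 to compound 4 (0.25 log units; within the scatter), the first single change measured at this position, which is ortho to a large group on the ring that also carries the bromo group. The step lies within the scatter, so the two compounds cannot be ranked, and going from 4-bromo-2-fluorophenyl to 4-bromo-2-methylphenyl leaves the number unchanged as far as this assay can tell, even though the two groups are different atoms of the same heavy-atom count. The data shown offer no reason why this step has the size it has.

As far as these compounds go, this single pair says nothing about groups at this position that differ more from fluoro and methyl, such as an amine, a carboxylic acid or a longer chain, or about a plain hydrogen there, so how far the insensitivity seen here extends remains unknown. It also leaves open whether the same swap would read the same way if the bromo group were replaced by another group, or on a different core.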